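The source may report more compounds than this note shows. Statements on the series, on what has been measured and on what is new or still open speak of the compounds shown alone.

Compound 1: `N#Cc1c(N)nc(SCc2cccc(C(N)=O)c2)c(C#N)c1-c1ccc(OCC2CC2)cc1` — 12.7 nM
Compound 2: `COC(=O)c1cccc(CSc2nc(N)c(C#N)c(-c3ccc(OCC4CC4)cc3)c2C#N)c1` — 347 nM

Among the compounds with values here, in a functional assay on CHO cells for agonist activity at adenosine receptor A2b (Homo sapiens), read by AlphaScreen and cAMP accumulation (a higher number here means that more compound is needed for the effect, a lower number that less compound is needed), compound 2 gives 347 nM, the higher of the two numbers measured so far; its nearest neighbour is compound 1, which gives 12.7 nM. Within the data shown here, the one measured step that connects them, a 27-fold higher number from compound 1 to compound 2 (1.44 log units; beyond the scatter), came from a single change, methoxy in place of amino on a carbonyl carbon, so swapping the amide of compound 1 for an ester weakened the response considerably.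

Compound 3, `CNC(=O)CSc1nc(N)c(C#N)c(-c2ccc(OCC3CC3)cc2)c1C#N`, has not yet been measured. It differs from compound 2 by methylcarbamoyl in place of 3-(methoxycarbonyl)phenyl on a saturated chain carbon bound to a sulfur: the whole aromatic ring with its ester leaves, and a short methylcarbamoyl group with one hydrogen-bond donor enters on the chain carbon bound to sulfur. Among the measured compounds shown here, no measured step covers the loss of the ring, but the only step known, the one from compound 1 to compound 2, shows that going from amide to ester costs a great deal, and compound 3 brings an amide back. A drop in this assay is therefore expected for compound 3, roughly an 8.7-fold lower number from compound 2 to compound 3 (0.94 log units; beyond the scatter), though the missing ring makes the size uncertain. Compound 3 is estimated at 40 nM, in a range from 8 nM to 250 nM.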

Compound 3, half-maximal effective concentration: 94 nM
Compound 3: the middle estimate sits 2.4-fold (0.37 log units) below what was measured; measured number inside the range.
By their numbers in this assay, from the lowest: compound 1; then compound 3; then compound 2.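

In this assay, the aromatic ring on the saturated chain carbon bound to a sulfur proves not to be essential for a response: replacing 3-(methoxycarbonyl)phenyl, with 10 heavy atoms, by methylcarbamoyl, with 4, gives a 3.7-fold lower number from compound 2 to compound 3 (0.57 log units; beyond the scatter) and so improves on the ester-bearing ring. Measured against the amide-bearing ring, the same small group fares worse: replacing 3-carbamoylphenyl by methylcarbamoyl gives a 7.4-fold higher number from compound 1 to compound 3 (0.87 log units; beyond the scatter) and so places compound 3 in the middle of the three. At this position, then, the effect of removing the ring depends on what the ring carries, and the ring with its amide gives the lowest number here, while the ring with its ester gives the highest.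

The compounds shown leave open how much of the difference belongs to the ring itself and how much to the group on it, which a plain phenyl ring, a carboxylic acid on the ring or a longer chain ending in the same amide could help to separate. Nothing available explains why these numbers shift as they do.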